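Aryl exchange on the ring nitrogen of compound 2

A few compounds are considered here, and "the series" means these few. Any claim that something is new, unique, unknown or untested is made for them only; others in the source may bear on it.

Two compounds of this series have numbers in a functional assay on A549 cells (Homo sapiens) for antiproliferative activity, read by MTT assay, with a stated time of 48 h; a higher number here means a weaker inhibitor, a lower number a stronger inhibitor. Compound 1 `N#CC1=C(N)Oc2c(c3nc4ccccc4nc3c3ccccc23)C12C(=O)N(Cc1cnnn1-c1ccc(Br)cc1)c1ccccc12` gives 44300 nM. Among the measured compounds shown here, compound 2 `N#CC1=C(N)Oc2c(N)cc3nc4ccccc4nc3c2C12C(=O)N(Cc1cnnn1-c1cccc(C(F)(F)F)c1)c1ccccc12` gives 5400 nM, the lowest of the two numbers; compound 1 is its only neighbour and sits at a higher number, beyond the scatter. For the measured compounds named here, both carry the shared core, but they differ in the aryl group on the aromatic nitrogen of the five-membered aromatic ring with 3 nitrogen and also in the substitution of the core itself, so no step between measured compounds that differ in one place is available.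

Compound 3 `COc1ccc(OC)c(-n2nncc2CN2C(=O)C3(C(C#N)=C(N)Oc4c(N)cc5nc6ccccc6nc5c43)c3ccccc32)c1` is not yet measured. It differs from compound 2 in one place: 2,5-dimethoxyphenyl in place of 3-(trifluoromethyl)phenyl on an aromatic nitrogen. Going by the values given here, nothing among the measured compounds isolates the effect of the aryl group on this nitrogen, since compound 1 and compound 2 also differ on the core. The expectation is therefore anchored on compound 2 at 5400 nM with a wide range. The step of a 1.3-fold higher number from compound 2 to compound 3 (0.11 log units; within the scatter) is expected to be small, in neither direction beyond the scatter. Compound 3 is estimated at 7000 nM, between 2500 nM and 20000 nM.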

Compound 3, half-maximal inhibitory concentration: 28100 nM
Estimate against measurement, compound 3: 4.0-fold (0.60 log units) below; the measured number lies above the stated range.
By their numbers in this assay, from the lowest: compound 2; then compounds 3 and 1 (each within the scatter of the next).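

In this assay, with the core held fixed, 2,5-dimethoxyphenyl in place of 3-(trifluoromethyl)phenyl on the aromatic nitrogen gives a 5.2-fold higher number from compound 2 to compound 3 (0.72 log units; beyond the scatter), so the activity of this series responds to the aryl group at this position. Among the compounds shown here, this is the first single-place reading at this nitrogen, since compound 1 and compound 2 differ on the core as well and cannot separate the two changes. The leaving and entering aryl groups have the same heavy-atom count and the same six-membered aromatic ring of carbon only, so the step accompanies an exchange of trifluoromethyl for two methoxy groups rather than a change in that count, and no measurement available here accounts for it.

Because the two aryl groups differ in more than one substituent, the compounds shown leave open whether the step follows the loss of trifluoromethyl, the presence of either methoxy group, or both together. An unsubstituted phenyl or a pyridine ring on the same nitrogen, with the core of compound 2 kept, would help to separate these readings.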